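This account rests on a few compounds, and the source may have more. Where it says the series, first, only, none or still open, it means among the compounds named here.

Measured to date in this series:

- compound 1 `Cc1cc(COc2ccccc2F)nc(-c2ccccn2)n1` — 398 nM
- compound 2 `CC(C)Nc1cc(COc2cccc(F)c2)nc(-c2ccccn2)n1` — 100 nM
- compound 3 `OC1CN(c2cc(COc3ccc(F)c(F)c3F)nc(-c3ccccn3)n2)C1` — 3160 nM

In a functional assay on cells for antagonist activity at Free fatty acid receptor 1 (Homo sapiens), read by TR-FRET and inositol phosphate accumulation, with a stated time of 2 h (on this read-out lower numbers stand for stronger inhibition and higher numbers for weaker inhibition), compound 3 stands at the highest of the three numbers. Compound 1 sits well below it, beyond the scatter, and compound 2 lies lower still, also beyond the scatter. Compounds 1 and 2 are the two with less at the position in question, whereas compound 3 carries the 3-hydroxyazetidin-1-yl ring there; the three compounds also differ in the fluorine pattern of the phenoxy part, so no single-point comparison exists among them.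

Compound 4 `Fc1ccc(OCc2cc(OCC(F)(F)F)nc(-c3ccccn3)n2)c(F)c1F` keeps the trifluorophenoxy part of compound 3 and changes only one place: 2,2,2-trifluoroethoxy in place of 3-hydroxyazetidin-1-yl on an aromatic carbon. For the measured compounds named here, with no measured pair isolating this position, the step has to be read from how compounds 1 and 2 stand against compound 3 in this assay. The expectation is a move downward beyond the scatter, toward the range of compound 1, but not as far as compound 2, with the step expected to be a 4.0-fold lower number from compound 3 to compound 4 (0.60 log units; beyond the scatter). Compound 4 is therefore estimated at 800 nM, within 250 nM to 2500 nM.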

Compound 4, half-maximal inhibitory concentration: 7.94 nM
Compound 4: middle estimate off by 100-fold (2.00 log units), on the high side; the whole stated range lies above it.
By their numbers in this assay, from the lowest: compound 4; then compound 2; then compound 1; then compound 3.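

In this assay, placing 2,2,2-trifluoroethoxy in place of 3-hydroxyazetidin-1-yl on an aromatic carbon, with the rest of the structure unchanged, gives a 400-fold lower number from compound 3 to compound 4 (2.60 log units; beyond the scatter). For the compounds shown here, this is the first comparison that isolates this position, opposite the ring nitrogen, from the fluorine pattern of the phenoxy part, and it shows that the group here alone can shift the number by a large margin. Nothing at hand explains the size of this step.

This single step does not separate the loss of the four-membered ring and its hydrogen-bond donor from the arrival of the fluorines; an ethoxy chain without fluorine and a 3-methoxyazetidin-1-yl ring would pull these apart. On these data alone, whether the step carries over to other phenoxy fluorine patterns also remains open.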